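Swapping carbamoyl for cyano on the shared core

The source may report more compounds than this note shows. Statements on the series, on what has been measured and on what is new or still open speak of the compounds shown alone.

- compound 1 `CCN1CCc2c(sc(NC(=O)Nc3ccc(Cl)cc3)c2C(N)=O)C1` in a functional assay (strain AB) with Danio rerio as the target, read by microscopy, with a stated time of 1 h (on this read-out higher numbers stand for an effect only at larger amounts of compound and lower numbers for an effect already at smaller amounts), gives 3120 nM
- compound 2 `NC(=O)c1c(NC(=O)Nc2ccc(Cl)cc2)sc2c1CCN(CC1CCC1)C2` in this assay gives 1360 nM

Of these two numbers, compound 1 holds the higher one. Among the measured compounds shown here, the only measured step, a 2.3-fold lower number from compound 1 to compound 2 (0.36 log units; beyond the scatter), has cyclobutyl in place of methyl on a saturated chain carbon bound to an amine nitrogen in a ring. Compound 3 `CCN1CCc2c(sc(NC(=O)Nc3ccc(Cl)cc3)c2C#N)C1` keeps the core of compound 1 but has cyano in place of carbamoyl on an aromatic carbon. The modest step to compound 2 lies at a different place in the molecule, so it bears on this change only as a hint of how far numbers can move in this small set. For the measured compounds named here, no measured pair shows the new swap. In this assay the best guess is therefore no step beyond the scatter, with no favoured direction and much uncertainty. The expected change is a 1.1-fold higher number from compound 1 to compound 3 (0.05 log units; within the scatter). For compound 3 the estimated value is 3500 nM, within an expected range from 900 nM to 14000 nM.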

Compound 3, half-maximal effective concentration: > 25000 nM
Compound 3: only a limit was reported; the forecaster's own chance of this, stated with the estimate: 20%; middle value at least 7.1-fold (0.85 log units) away from the limit.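

Compound 1 and compound 2 both carry carbamoyl, so only compound 3 tests this position on the shared core, and there the change counts for a great deal in this assay: the swap to cyano gives an at least 8.0-fold higher number from compound 1 to compound 3 (0.90 log units; beyond the scatter). Of the two groups, carbamoyl has 1 hydrogen-bond donor and cyano has 0, but a single swap cannot show whether that difference is what matters. Compound 3 carries a limit and not a number, so the step has no known upper end: the limit of > 25000 nM in this assay, at which 1 of the 3 values shown sits.

The compounds shown leave open how a carboxylic acid or an aminomethyl group would fare on this aromatic carbon. They also leave open whether cyano would cost as much on the core of compound 2, which has the cyclobutyl group.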